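Propyl in Place of Isopropyl: Limits and an Expectation

The source may hold more compounds than are shown below. What is called first, only, known or untested is meant among the compounds shown, and "the series" means these compounds.

Compound 1 `CC(C)c1ncn2c(O)nncc12` shows in a functional assay for inhibition, with Homo sapiens as the target (a lower number here means a stronger inhibitor, a higher number a weaker inhibitor), only a limit, > 48000 nM.
Compound 2 `CCCc1ncn2c(O)nncc12` shows in this assay only a limit, > 48000 nM.
Compound 3 `Cc1nc(C(C)C)n2c(S)nncc12` shows in this assay only a limit, > 48000 nM.

All three measured values sit at the same limit, as the limit of > 48000 nM in this assay, at which 3 of the 3 values shown sit, records. The change propyl in place of isopropyl on an aromatic carbon gives a step that the two limits leave unreadable from compound 1 to compound 2. Compound 4 `CCCc1nc(C)c2cnnc(S)n12` arises from compound 3 by the same kind of change, (propyl in place of isopropyl on an aromatic carbon); the surroundings differ, since in compound 1 the carbon is next to the ring nitrogen, two ring bonds from the ring nitrogen, whereas in compound 3 it is between two ring nitrogen atoms, two ring bonds from the ring atom that bears a methyl group. The difference between the two cores is not broken down here. Because compound 3 reached only the limit, compound 4 is expected to give a step that the limit leaves unreadable from compound 3 to compound 4, most likely again only a limit; the estimate for compound 4 is 80000 nM, between 30000 nM and 300000 nM.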

Compound 4, half-maximal inhibitory concentration: 10000 nM
Beside the measured number, compound 4's estimate is 8.0-fold (0.90 log units) above it, outside the stated range (below it).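

In this assay, propyl in place of isopropyl on an aromatic carbon gives an at least 4.8-fold lower number from compound 3 to compound 4 (0.68 log units; beyond the scatter), a readable gain on the core of compound 3, though only a minimum for its size. This does not show that the change carries over to another core, and one pair cannot establish a rule. The same change on the core of compound 1 cannot be read, and it neither supports nor contradicts this result, with both of its compounds at the limit: the limit of > 48000 nM in this assay, at which 3 of the 4 values shown sit.

The compounds shown leave open whether a longer chain such as butyl, or an amine, on this aromatic carbon would lower the number further. They also leave open which of the differences between the two cores matters for the change.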